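The source may report more compounds than this note shows. Statements on the series, on what has been measured and on what is new or still open speak of the compounds shown alone.

Among the compounds with values here, compound 3 `COc1cc2c(=O)c(C(=O)c3ccc(C)cc3)cn(Cc3ccc(Cl)cc3)c2cc1OC` is the one compound of the three whose result in an ADME assay on Huh-7 cells (Homo sapiens) for cytotoxicity (on this read-out lower numbers stand for stronger inhibition of growth and higher numbers for weaker inhibition of growth), is a number: compound 3 gives 15500 nM. Compound 1 `COc1cc2c(=O)c(C(=O)c3ccc(C)cc3)cn(Cc3ccc(S(N)(=O)=O)cc3)c2cc1OC` reaches only a limit of this assay, at which compound 1 gives > 25000 nM. Compound 2 `COc1cc2c(=O)c(C(=O)c3ccc(C)cc3)cn(Cc3ccc(C(F)(F)F)cc3F)c2cc1OC` likewise reaches a limit of this assay, and compound 2 gives > 25000 nM. Two of the three values therefore sit at the same boundary (the limit of > 25000 nM in this assay, at which 2 of the 3 values shown sit), so the measured steps say little: an at least 1.6-fold lower number from compound 1 to compound 3 (0.20 log units; that floor lies within the scatter) and an at least 1.6-fold lower number from compound 2 to compound 3 (0.20 log units; that floor lies within the scatter) both have floors within the scatter, and a step that the two limits leave unreadable from compound 1 to compound 2 cannot be read at all.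

Compound 4 `CCOC(=O)c1cn(Cc2ccc(Cl)cc2)c2cc(OC)c(OC)cc2c1=O` differs from compound 3 in one place: ethoxy in place of 4-methylphenyl on a carbonyl carbon. Within the data shown here, none of the measured steps touches that carbonyl carbon; all three alter the group on the saturated chain carbon bound to the aromatic nitrogen, while compound 3 and compound 4 share the 4-chlorophenyl there. Nothing measured here therefore bears on the change from compound 3 to compound 4, and no step beyond the scatter is expected in this assay: the estimated step is a 1.2-fold higher number from compound 3 to compound 4 (0.06 log units; within the scatter). Compound 4 is accordingly expected to give about 18000 nM in this assay, within a range from 7000 nM to 40000 nM, with a fair chance that only a limit is reported.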

Compound 4, concentration for 50% growth inhibition: > 15000 nM
Compound 4: no number, only a limit (the forecaster's own chance of this, stated with the estimate: 45%); the middle value lies beyond the limit too.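

In this assay compound 4 gives > 15000 nM as a limit and not a number. Within the data shown here, no new step can therefore be read from compound 3 to compound 4. The compounds shown leave open whether ethoxy in place of 4-methylphenyl on a carbonyl carbon changes the growth-inhibition read-out at all, and in which direction.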